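A few compounds are considered here, and "the series" means these few. Any claim that something is new, unique, unknown or untested is made for them only; others in the source may bear on it.

Compound 1, `CN1CCC(OC(=O)c2ccccc2F)CC1`, was tested in a functional assay on the whole organism with Mus musculus as the target (on this read-out lower numbers stand for lower potency and higher numbers for higher potency (the scale is a negative logarithm)), where compound 1 gives 1.41. Going by the values given here, the only other measured member of the set is compound 2, `COc1cccc(C(=O)OC2CCN(C)CC2)c1OC`, and in this assay compound 2 gives 1.55. The two values lie within the usual scatter of each other, so compound 1 cannot be placed above or below compound 2 on this read-out; it simply stands alongside it at the lower end of a narrow pair of numbers. Compound 3, `CN1CCC(OC(=O)c2ccccc2C(F)(F)F)CC1`, has not yet been measured in this assay. It differs from compound 1 in one place: trifluoromethyl in place of fluoro on an aromatic carbon. Among the compounds with values here, no measured pair in this set changes the same position, so there is no step to lean on. The account therefore expects only a small step from compound 1 to compound 3, a number 0.19 log units higher from compound 1 to compound 3 (within the scatter), not clearly beyond the scatter and with an uncertain direction. For compound 3 the estimated value in this assay is 1.6, with a range from 1.1 to 2.1.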

Compound 3, logarithm of the reciprocal of the active concentration, log(1/C): 1.49
Beside the measured number, compound 3's estimate is 0.11 log units above it; the measured number falls inside the stated range.
By their numbers in this assay, from the lowest: compounds 1, 3 and 2 (each within the scatter of the next).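

In this assay, going by these compounds alone, the change from fluoro to trifluoromethyl on an aromatic carbon, ortho to a large group, gives a number 0.08 log units higher from compound 1 to compound 3 (within the scatter) and so supplies the first measured step at this position. It shows that a group of 4 heavy atoms can take the place of a group of 1 heavy atom here with no change beyond the scatter, so this read-out does not separate the two groups. No measured finding on either group bears on this result.

As far as these compounds go, whether a group of another kind at this place, such as an amine or a carboxylic acid, would move the number beyond the scatter stays open. Also open, from the compounds shown here alone, is whether the same change would give a similar step on the core of compound 2.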